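The compounds below may be only part of what the source reports. "The series", "measured", "known", "first", "only" and "open" are said of these compounds alone.

Compound 1 `CSc1ccc2nc(C)cc(OCC(=O)Nc3cc(C)cc(C)c3)c2c1`: 3000 nM
Compound 2 `COc1ccc2nc(C)cc(OC3CCN(c4ccccc4)C3=O)c2c1`: 215000 nM
Compound 3 `COc1ccc2nc(C)cc(OCC(=O)Nc3cccc(C)c3)c2c1`: 193000 nM

In a physicochemical assay for solubility, in phosphate buffer, measured as kinetic solubility, with a stated time of 1 h, at pH 7.4 (a lower number here means a less soluble compound, a higher number a more soluble compound), compound 3 gives 193000 nM, the second highest of the three numbers. Compound 2 gives 215000 nM, which sits within the scatter of compound 3, so the two cannot be told apart. Going by the values given here, compound 1 gives 3000 nM, far lower than compound 3 and well beyond the scatter; compound 1 differs from compound 3 in more than one place, so no single step connects them.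

Compound 4 `COc1ccc2nc(C)cc(OCC(=O)Nc3cc(C)c(F)c(C)c3)c2c1` has not yet been measured in this assay. It differs from compound 3 in one place: 4-fluoro-3,5-dimethylphenyl in place of 3-methylphenyl on an amide-type nitrogen. Among the compounds with values here, no measured pair shows this exact change, so the expected step rests on the structural change alone and on the low value of compound 1. A drop in this assay beyond the scatter is expected for compound 4, with an estimated step of a 6.4-fold lower number from compound 3 to compound 4 (0.81 log units; beyond the scatter). Compound 4 is therefore estimated at 30000 nM, with a likely range from 5000 nM to 120000 nM.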

Compound 4, solubility: 31500 nM
Beside the measured number, compound 4's estimate is 1.1-fold (0.02 log units) below it; the measured number falls inside the stated range.
By their numbers in this assay, from the lowest: compound 1; then compound 4; then compounds 3 and 2 (each within the scatter of the next).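

In this assay, going by these compounds alone, the group on the amide-type nitrogen gives the first single change that can be read, and 4-fluoro-3,5-dimethylphenyl in place of 3-methylphenyl gives a 6.1-fold lower number from compound 3 to compound 4 (0.79 log units; beyond the scatter). This shows that the number at this position is not indifferent to what the phenyl group carries, at least for this one pair. Nothing measured here offers a reason for the drop.

From the compounds shown here alone, the entering group adds a fluorine and a second methyl in the same step, so the share of each remains unknown. The compounds shown also leave open how the number would respond to a quite different group on this phenyl, such as an amine or a carboxylic acid, or to a longer chain on the amide-type nitrogen.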